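A few compounds are considered here, and "the series" means these few. Any claim that something is new, unique, unknown or untested is made for them only; others in the source may bear on it.

Compound 1 `CC(C)(NC(=O)Nc1ccc(F)c(C(F)(F)F)c1)C(=O)O` was run in an ADME assay on microsomes from liver (Mus musculus) for metabolic stability, using NADPH, with a stated time of 60 min; on this read-out lower numbers stand for slow clearance and higher numbers for fast clearance. In this assay compound 1 gives < 7 uL/min, which is a limit of the assay rather than a number. Two other compounds sit at the same place. In this assay compound 2 `CC(C)(NC(=O)Nc1ccccc1)C(=O)O` gives < 7 uL/min, again a limit. In this assay compound 3 `CC(C)(C(=O)O)N1CCCN(c2ccc(F)c(C(F)(F)F)c2)C1=O` gives < 7 uL/min, also a limit. Among the compounds with values here, all three values rest at the limit of < 7 uL/min in this assay, at which 3 of the 3 values shown sit, so compound 1 stands where the assay stops distinguishing slow clearance, and no measured step between compounds can be drawn from them. Compound 4 `CC(C)(CC(=O)Nc1ccc(F)c(C(F)(F)F)c1)C(=O)O` differs from compound 1 in one place: 2-carboxy-2-methylpropyl in place of (1-carboxy-1-methylethyl)amino on a carbonyl carbon. With every value at the limit, no step beyond the usual scatter is expected, and the estimated step that the limit leaves unreadable from compound 1 to compound 4 is small. Compound 4 is expected to give 6 uL/min, between 3 uL/min and 15 uL/min, most likely again reported only as a limit.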

Compound 4, intrinsic clearance in a liver preparation (reported as CLH), per the amount of preparation that the assay uses: < 7 uL/min
Compound 4 was reported as a limit (the forecaster's own chance of this, stated with the estimate: 70%); the middle value does not contradict the limit.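

Within the data shown here, no step from compound 1 to compound 4 can be read, because both values are limits of the assay: the limit of < 7 uL/min in this assay, at which 4 of the 4 values shown sit.

The compounds shown leave open whether their clearances truly differ, and which change would give a value off this limit.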